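Ring Size on the Amide Carbonyl in an mGlu5 Modulator Series

The source may report more compounds than this note shows. Statements on the series, on what has been measured and on what is new or still open speak of the compounds shown alone.

Of the compounds shown here, three built on a shared core have been measured. Compound 1 `O=C(c1ccc(F)cc1F)N1CCCC[C@@H]1c1nc(-c2cccc(F)c2)no1` is the one with a six-membered saturated ring bearing the amide; in an in vitro functional assay on HEK293-A cells for positive allosteric modulation of metabotropic glutamate receptor 5 (Homo sapiens), read by fluorescence and calcium flux, with a stated time of 140 s (on this read-out higher numbers stand for an effect only at larger amounts of compound and lower numbers for an effect already at smaller amounts), compound 1 gives 2900 nM. Compound 2 `O=C(C1CCC1)N1CCCC1c1nc(-c2cccc(F)c2)no1` carries a smaller saturated ring next to the oxadiazole and a different ring on the carbonyl; in this assay compound 2 gives 1500 nM; 1500 nM (2 entries). Compound 3 `O=C(C1CC1)N1CCCC1c1nc(-c2cccc(F)c2)no1` keeps the same core as compound 2. In this assay compound 3 gives 2900 nM, which is level with compound 1 at the digits shown and within the usual scatter of compound 2.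

Compound 4 `O=C(C1CCCC1)N1CCCC1c1nc(-c2cccc(F)c2)no1` has not yet been measured. It differs from compound 3 by one change: cyclopentyl in place of cyclopropyl on a carbonyl carbon. Among the measured compounds shown here, no pair of measured compounds differing in exactly one place has been recorded, so the size of this step is not known from direct comparison. Since the values of compound 2 and compound 3 lie within the scatter of each other, the step to compound 4 is expected to be small, with no clear direction beyond the scatter. Compound 4 is therefore estimated at 1800 nM, in the range from 700 nM to 5000 nM, which corresponds to an expected step of a 1.6-fold lower number from compound 3 to compound 4 (0.21 log units; within the scatter).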

Compound 4, half-maximal effective concentration: 1000 nM
For compound 4 the middle estimate is 1.8-fold (0.26 log units) above the measured one, within the range that was stated.
By their numbers in this assay, from the lowest: compound 4; then compounds 1 and 3 (each within the scatter of the next).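

In this assay, among the compounds shown here, the swap of cyclopropyl for cyclopentyl on a carbonyl carbon gives a 2.9-fold lower number from compound 3 to compound 4 (0.46 log units; beyond the scatter) and so provides the first direct comparison in this set, in which only one place changes. The step is modest, but it lies beyond the usual scatter, so the group at this position does affect the amount of compound needed, and the larger carbon ring is accepted here without any loss on this read-out. The data offer nothing that explains the shift, and the two groups are compared here only by their names and ring sizes.

Going by these compounds, one step between two ring sizes gives no rule for this position, so it remains open how a cyclohexyl ring, an open chain such as tert-butyl, or a ring containing oxygen such as tetrahydropyranyl would behave in the same place. On these data alone, it also remains open whether the same swap would produce a step of similar size on the core of compound 1, where the carbonyl carries a different group and the nitrogen ring is larger.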